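The compounds below may be only part of what the source reports. "The series", "measured", "known", "first", "only" and "open" are said of these compounds alone.

Working notes on the series. Compound 2 `Cc1nc(C(NC(=O)C(=O)Nc2ccc(F)c(F)c2)C2CCCCN2)sc1CCO` is the reference point here. In an ADME assay on TZM-b1 cells (Homo sapiens) for cytotoxicity, read by XTT assay, with a stated time of 3 days (on this read-out higher numbers stand for lower toxicity in this test and lower numbers for higher toxicity in this test), compound 2 gives > 78200 nM, which is a limit of the measurement and not a number. That reading sits at the limit of > 78200 nM in this assay, at which 1 of the 2 values shown sits, so compound 2 stands only at a limit within what is shown. Compound 1 `Cc1nc(C(NC(=O)C(=O)Nc2ccc(Cl)cc2)C2CCCCN2)sc1CO` has been run in this assay as well; compound 1 gives > 22000 nM, again a limit rather than a number. This reading is the limit of > 22000 nM in this assay, at which 1 of the 2 values shown sits. Among the compounds with values here, both values in hand are thus limits, and no step between measured compounds can be drawn from them.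

Compound 3 `Cc1nc(C(NC(=O)C(=O)Nc2ccc(Cl)cc2)C2CCCCN2)sc1CCO` is not yet measured. It differs from compound 2 by 4-chlorophenyl in place of 3,4-difluorophenyl on an amide-type nitrogen; compound 1 also carries the 4-chlorophenyl group on the amide-type nitrogen. With both measured compounds resting at limits, no change beyond the usual scatter is expected in this assay, and the expected step from compound 2 to compound 3 is an at least 1.3-fold lower number from compound 2 to compound 3 (0.11 log units; that floor lies within the scatter). Compound 3 is estimated at 60000 nM in this assay, with a range of 20000 nM to 150000 nM, and a limit reading is the more likely outcome.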

Compound 3, half-maximal cytotoxic concentration: 32800 nM
For compound 3 the middle estimate is 1.8-fold (0.26 log units) above the measured one; measured number inside the range.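

In this assay, within the data shown here, compound 3 gives 32800 nM, the first reading in this set that is a number and not a limit. On the amide-type nitrogen, 4-chlorophenyl in place of 3,4-difluorophenyl gives an at least 2.3-fold lower number from compound 2 to compound 3 (0.37 log units; beyond the scatter), which shows that a change at this place can lower the number in this test, and the printed size is only a floor: the limit of > 78200 nM in this assay, at which 1 of the 3 values shown sits. The step between compound 1 and compound 3, where the chain on the shared core changes with the 4-chlorophenyl group held constant, cannot be read: the limit of > 22000 nM in this assay, at which 1 of the 3 values shown sits.

The compounds shown leave open whether the lower number follows from the 4-chlorophenyl group itself or from the loss of the 3,4-difluorophenyl group, which a plain phenyl or a 4-fluorophenyl group on the same nitrogen would help to separate. They also leave open how far the chain end matters once a number is available, and a longer hydroxyalkyl chain or a carboxylic acid at that place, with 4-chlorophenyl retained, would test this.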